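Halogen pattern on the benzamide ring: compound 3

This account rests on a few compounds, and the source may have more. Where it says the series, first, only, none or still open, it means among the compounds named here.

Compound 2 `CN1CCN(c2ccc(Nc3nc(-c4cccc(NC(=O)c5ccc(Cl)cc5)c4)sc3C(N)=O)cc2)CC1` gives 1360 nM in a functional assay on Ramos cells (Homo sapiens) for antiproliferative activity, read by CCK-8 assay, with a stated time of 72 h (on this read-out higher numbers stand for weaker inhibition and lower numbers for stronger inhibition), the lowest of the two numbers at hand, with compound 1 `CN1CCN(c2ccc(Nc3nc(-c4cccc(NC(=O)c5ccc(F)cc5)c4)sc3C(N)=O)cc2)CC1` nearest at 1420 nM; the two lie within the scatter. Compound 3 `CN1CCN(c2ccc(Nc3nc(-c4cccc(NC(=O)c5ccc(F)c(Cl)c5)c4)sc3C(N)=O)cc2)CC1` differs from compound 2 by 3-chloro-4-fluorophenyl in place of 4-chlorophenyl on a carbonyl carbon. For the measured compounds named here, the only measured step touching this ring, a 1.0-fold lower number from compound 1 to compound 2 (0.02 log units; within the scatter), stayed within the scatter, so adding a further halogen to the same ring is not expected to move the number beyond the scatter either. Compound 3 is therefore expected to give 1300 nM, between 600 nM and 2800 nM, which means an expected 1.0-fold lower number from compound 2 to compound 3 (0.02 log units; within the scatter).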

Compound 3, half-maximal inhibitory concentration: 4830 nM
Beside the measured number, compound 3's estimate is 3.7-fold (0.57 log units) below it; the measured number lies above the stated range.
By their numbers in this assay, from the lowest: compounds 2 and 1 (each within the scatter of the next); then compound 3.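

In this assay the phenyl on the carbonyl carbon responds to its halogen pattern, which the fluoro and chloro pair of compound 1 and compound 2 did not show: 3-chloro-4-fluorophenyl in place of 4-chlorophenyl gives a 3.6-fold higher number from compound 2 to compound 3 (0.55 log units; beyond the scatter) and a further chloro on the fluoro-bearing ring gives a 3.4-fold higher number from compound 1 to compound 3 (0.53 log units; beyond the scatter) in the same direction. Both steps are modest, and the second isolates the added chloro. Nothing at hand bears on the reason for this loss.

Open, from the compounds shown here alone, is whether the loss is specific to chloro, or whether a methyl, a methoxy or an amino group in its place would give the same number.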